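Sulfonamide Analogue of an Inactive Alkyl Ether Series

This account rests on a few compounds, and the source may have more. Where it says the series, first, only, none or still open, it means among the compounds named here.

Measured compounds:
- compound 1, `CCCCCCCCCCCCCCCCCCOCC(CC[S+]([O-])c1ccc(C)cc1)NC(C)=O`: > 200000 nM
- compound 2, `CCCCCCCCCCCCCCCCCCOCC(CCC1CO1)NC(C)=O`: > 200000 nM
- compound 3, `CCCCCCCCCCCCCCCCCCOCC(CCCO)NC(C)=O`: > 200000 nM

Of the compounds shown here, three sharing a long alkyl ether core have been tested in an assay for inhibition of putative inactive group IIC secretory phospholipase A2 (Homo sapiens); a higher number here means a weaker inhibitor, a lower number a stronger inhibitor. For compound 1 only a limit is known, > 200000 nM, not a number. The same is true of compound 2, which sits at its limit of > 200000 nM. Compound 3 likewise reaches only the limit > 200000 nM. All three therefore stand at the limit of > 200000 nM in this assay, at which 3 of the 3 values shown sit, and the steps among them cannot be read: a step that the two limits leave unreadable from compound 1 to compound 2, a step that the two limits leave unreadable from compound 1 to compound 3 and a step that the two limits leave unreadable from compound 2 to compound 3. In short, compound 1 stands where every measured compound stands, at a limit and nowhere on a scale of real numbers.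

The new compound 4, `CCCCCCCCCCCCCCCCCCOCC(CNS(=O)(=O)c1ccc(C)cc1)NC(C)=O`, is drawn from compound 1 by the change (a group of 11 heavy atoms (7 carbon, 1 nitrogen, 2 oxygen, 1 sulfur; one six-membered aromatic ring of carbon only) in place of a group of 10 heavy atoms (8 carbon, 1 oxygen, 1 sulfur; one six-membered aromatic ring of carbon only), on a saturated chain carbon, two bonds along the chain from an amide-type nitrogen).

Among the measured compounds shown here, none of the measured steps gives a readable size, so nothing here argues that a group of this kind on the chain turns an inactive compound into an active one. The expectation for compound 4 in this assay is therefore that it, too, will most likely be reported only as a limit, with an expected step that the limit leaves unreadable from compound 1 to compound 4. The estimate for compound 4 is 300000 nM, within a range from 100000 nM to 1000000 nM.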

Compound 4, half-maximal inhibitory concentration: > 200000 nM
Compound 4 was reported as a limit; the forecaster's own chance of this, stated with the estimate: 85%; the middle value does not contradict the limit.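

In this assay compound 4 gives > 200000 nM, which is a limit and not a number. Its steps from compound 1, compound 2 and compound 3 therefore cannot be read, and all four compounds stand at the same point: the limit of > 200000 nM in this assay, at which 4 of the 4 values shown sit. The compounds shown leave open whether any change to the shared core would give a measurable value in this assay.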